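This account rests on a few compounds, and the source may have more. Where it says the series, first, only, none or still open, it means among the compounds named here.

Measured in a functional assay on A549 cells (Homo sapiens) for antiproliferative activity, read by MTT assay, with a stated time of 24 h; a higher number here means a weaker inhibitor, a lower number a stronger inhibitor:
- Compound 1 `O=S(=O)(c1ccccc1)n1c(-c2cn(-c3ccccc3)nc2-c2ccc(F)cc2)nc2ccccc21`: 550 nM
- Compound 2 `COc1ccc(S(=O)(=O)n2c(-c3cn(-c4ccccc4)nc3-c3ccc(F)cc3)nc3ccccc32)cc1`: 350 nM
- Compound 3 `O=S(=O)(c1ccc(Cl)cc1)n1c(-c2cn(-c3ccccc3)nc2-c2ccc(F)cc2)nc2ccccc21`: 3170 nM

Compound 2 stands at the low end of these numbers: a 1.6-fold lower number from compound 1 to compound 2 (0.20 log units; within the scatter), whereas a 9.1-fold higher number from compound 2 to compound 3 (0.96 log units; beyond the scatter). Compound 4 `COc1ccc(S(=O)(=O)n2c(-c3cn(-c4ccccc4)nc3-c3ccc(C(F)(F)F)cc3)nc3ccccc32)cc1` differs from compound 2 by trifluoromethyl in place of fluoro on an aromatic carbon. Within the data shown here, no measured step touches this site. The steps elsewhere offer only a rough guide to size: a 5.8-fold higher number from compound 1 to compound 3 (0.76 log units; beyond the scatter) shows that one aromatic substituent swap can move the number modestly. A modest rise is therefore expected, though a result within the scatter would be unsurprising. The expected change is a 1.6-fold higher number from compound 2 to compound 4 (0.20 log units; within the scatter). For compound 4, the estimated value is 550 nM, with an expected range of 170 nM to 1800 nM.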

Compound 4, half-maximal inhibitory concentration: 170 nM
Compound 4: middle estimate off by 3.2-fold (0.51 log units), on the high side, and the stated range covers the measured number.
By their numbers in this assay, from the lowest: compound 4; then compounds 2 and 1 (each within the scatter of the next); then compound 3.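

In this assay, among these compounds, a 2.1-fold lower number from compound 2 to compound 4 (0.31 log units; beyond the scatter), the first reading at this position, which the earlier compounds left unchanged while varying another aromatic substituent. It shows that this site affects the number and that replacing fluoro with trifluoromethyl here lowers it modestly rather than raising it. No supporting measurement bears on why this happens.

From the compounds shown here alone, whether an amine or a carboxylic acid at this position would lower the number further remains open. So does whether the same change would lower it in the settings of compound 1 and compound 3.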